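Exchanging the azido group on compound 2

The compounds below may be only part of what the source reports. "The series", "measured", "known", "first", "only" and "open" are said of these compounds alone.

In a functional assay on HCT-116 cells (Homo sapiens) for inhibition, read by MTT assay, with a stated time of 48 h (a lower number here means a stronger inhibitor, a higher number a weaker inhibitor), compound 1 `COc1ccc(CN(C(=O)C(C)Br)c2cc(OC)c(OC)c(OC)c2)cc1O` gives 140 nM, while compound 2 `COc1ccc(CN(C(=O)CN=[N+]=[N-])c2cc(OC)c(OC)c(OC)c2)cc1O` gives 410 nM. Among the compounds with values here, compound 2 therefore has the higher of the two numbers so far and is the weaker inhibitor of this pair. The next compound, compound 3 `COc1ccc(CN(C(=O)C[Se]C#N)c2cc(OC)c(OC)c(OC)c2)cc1O`, keeps the rest of compound 2 and exchanges one group: a group of 3 heavy atoms (1 carbon, 1 nitrogen, 1 selenium; no ring) in place of a group of 3 heavy atoms (3 nitrogen; no ring), on a saturated chain carbon bound to a carbonyl carbon.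

Within the data shown here, only one measured step bears on this exchange, and it also swaps a group, in that case on a carbonyl carbon: a 2.9-fold higher number from compound 1 to compound 2 (0.47 log units; beyond the scatter). That is a modest step, though beyond the usual scatter. Among the measured compounds shown here, a single step is thin evidence, and no measured compound yet carries the incoming group. A step of similar modest size is the reasonable expectation, but its direction is uncertain. A lower number seems slightly more likely, as compound 2 sits at the upper end with 410 nM. The expected change is a 2.3-fold lower number from compound 2 to compound 3 (0.36 log units; beyond the scatter). In this assay, the estimate for compound 3 is 180 nM, with an expected range of 40 nM to 800 nM.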

Compound 3, half-maximal inhibitory concentration: 310 nM
Estimate against measurement, compound 3: 1.7-fold (0.24 log units) below, and the stated range covers the measured number.
By their numbers in this assay, from the lowest: compound 1; then compounds 3 and 2 (each within the scatter of the next).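

In this assay, placing the group of 3 heavy atoms (1 carbon, 1 nitrogen, 1 selenium) on the saturated chain carbon bound to a carbonyl carbon in place of azido gives a 1.3-fold lower number from compound 2 to compound 3 (0.12 log units; within the scatter), so this assay does not tell these two groups apart. The comparison with the bromine compound gives a 2.2-fold higher number from compound 1 to compound 3 (0.35 log units; beyond the scatter), which is beyond the scatter and has the same direction as a 2.9-fold higher number from compound 1 to compound 2 (0.47 log units; beyond the scatter), so compound 1 now holds the lowest number, with both of the other compounds clearly separated from it. No measurement shown here accounts for these numbers.

Compound 1 carries a 1-bromoethyl group, while compounds 2 and 3 have neither its bromine nor its extra methyl, so these compounds cannot show which of the two features goes with its lower number. A bromomethyl group or a plain ethyl group on the carbonyl carbon would separate the two, and an amine on the chain carbon would show whether the flat response between compounds 2 and 3 extends to a quite different group.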